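A few compounds are considered here, and "the series" means these few. Any claim that something is new, unique, unknown or untested is made for them only; others in the source may bear on it.

Working notes on the series. Compound 1 `CC(C)CCn1nc(-c2cccs2)c(O)c(C2=NS(=O)(=O)c3cc(O)ccc3N2)c1=O` gives 0.0933 h in an in vitro ADME assay on microsomes from liver (Homo sapiens) for metabolic stability, tested at 5 uM; on this read-out lower numbers stand for a shorter-lived compound and higher numbers for a longer-lived compound. Compound 2 `CC(C)CCn1nc(-c2cccs2)c(O)c(C2=NS(=O)(=O)c3cc(OCC#N)ccc3N2)c1=O` gives 0.25 h in this assay, and compound 3 `CC(C)CCn1nc(-c2cccs2)c(O)c(C2=NS(=O)(=O)c3cc(NC(=O)C4CC4)ccc3N2)c1=O` gives 0.0833 h. Compound 3 stands at the lowest of the three numbers: one of the steps ending at it is a 1.1-fold lower number from compound 1 to compound 3 (0.05 log units; within the scatter), within the scatter, while the other is a 3.0-fold lower number from compound 2 to compound 3 (0.48 log units; beyond the scatter). Within the data shown here, the only step beyond the scatter among the measured pairs is a 2.7-fold higher number from compound 1 to compound 2 (0.43 log units; beyond the scatter).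

Compound 4 `CC(=O)c1ccc2c(c1)S(=O)(=O)N=C(c1c(O)c(-c3cccs3)nn(CCC(C)C)c1=O)N2` is not yet measured in this assay. It differs from compound 3 in one place: acetyl in place of (cyclopropylcarbonyl)amino on an aromatic carbon. Among the measured compounds shown here, no measured step brings acetyl in, so no step bears directly on this change. The two steps that set (cyclopropylcarbonyl)amino at this carbon, a 1.1-fold lower number from compound 1 to compound 3 (0.05 log units; within the scatter) and a 3.0-fold lower number from compound 2 to compound 3 (0.48 log units; beyond the scatter), bear on it only in part; together with the cluster of all three numbers in a narrow band, they suggest exchanges at this position have moved this assay by at most modest amounts.

For compound 4 a step in this assay of about a 1.4-fold higher number from compound 3 to compound 4 (0.16 log units; within the scatter) is therefore expected, upward if anything but not clearly beyond the scatter. Compound 4 is expected to give 0.12 h in this assay, estimated within 0.05 h to 0.32 h.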

Compound 4, half-life: 0.0717 h
For compound 4 the middle estimate is 1.7-fold (0.22 log units) above the measured one; measured number inside the range.
By their numbers in this assay, from the lowest: compounds 4, 3 and 1 (each within the scatter of the next); then compound 2.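

In this assay, acetyl at this aromatic carbon leaves the number in the same band as the two other groups: a 1.2-fold lower number from compound 3 to compound 4 (0.07 log units; within the scatter) and a 1.3-fold lower number from compound 1 to compound 4 (0.11 log units; within the scatter) both stay within the scatter, so hydroxy, (cyclopropylcarbonyl)amino and acetyl cannot be told apart on this read-out, even though the exchange for acetyl removes the three-membered ring and the hydrogen-bond donor of the leaving group. With a 3.5-fold lower number from compound 2 to compound 4 (0.54 log units; beyond the scatter) beyond the scatter, compound 2 is now the only one of the four whose steps to all the others are printed as beyond the scatter, which sets cyanomethoxy apart from three different groups at this position rather than from two. Nothing at hand gives a reason for this separation.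

From the compounds shown here alone, whether the separation of compound 2 follows the ether oxygen, the nitrile or the two together stays open; a methoxy group or a longer alkoxy chain at this carbon would bear on that. Also open, going by these compounds, is whether an amine or a carboxylic acid here would stay in the band of compound 1, compound 3 and compound 4 or leave it.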